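Methoxy to hydroxy: an expected step for compound 3

This account rests on a few compounds, and the source may have more. Where it says the series, first, only, none or still open, it means among the compounds named here.

Measured compounds:
Compound 1 `O=C(Nc1cccc(-n2cc(-c3ccncc3)c(-c3ccc(Cl)c(O)c3)n2)c1)Nc1cccc(C(F)(F)F)c1` gives 1330 nM in a functional assay on KM12 cells (Homo sapiens) for inhibition, read by sulforhodamine B assay, with a stated time of 48 h; on this read-out lower numbers stand for stronger inhibition and higher numbers for weaker inhibition.
Compound 2 `COc1cc(-c2nn(-c3cccc(NC(=O)Nc4ccc(Cl)c(Cl)c4)c3)cc2-c2ccncc2)ccc1Cl` gives 810 nM in this assay.

Within the data shown here, compound 2 stands at the lowest of the two numbers so far, but its nearest neighbour, compound 1, lies within the usual scatter of it, so the two cannot be placed in order on this assay alone. Compound 3 `O=C(Nc1cccc(-n2cc(-c3ccncc3)c(-c3ccc(Cl)c(O)c3)n2)c1)Nc1ccc(Cl)c(Cl)c1` has not yet been measured. It differs from compound 2 in one place: hydrogen in place of methyl on an oxygen on an aromatic ring. Among the measured compounds shown here, no step between two measured compounds shows this change directly, so there is nothing in the data to give it a size or a direction. For the measured compounds named here, the only pointer is that compound 1, which already carries the hydroxy form of this ring, sits within the scatter of compound 2. On that basis compound 3 is expected to come out close to compound 2, with the step of a 1.0-fold higher number from compound 2 to compound 3 (0.02 log units; within the scatter) expected to stay inside the scatter in this assay. The estimate for compound 3 is 850 nM, with a range from 300 nM to 2500 nM.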

Compound 3, half-maximal inhibitory concentration: 1010 nM
Compound 3: the middle estimate sits 1.2-fold (0.07 log units) below what was measured, within the range that was stated.
By their numbers in this assay, from the lowest: compounds 2, 3 and 1 (each within the scatter of the next).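

The methoxy to hydroxy change on the 4-chloro-3-methoxyphenyl ring now has a measured size in this assay (a 1.2-fold higher number from compound 2 to compound 3 (0.10 log units; within the scatter)), so on this read-out hydrogen and methyl on that oxygen cannot be told apart. Among these compounds, the result also gives the first one-place reading on the other side of the molecule: with the hydroxy form kept, 3,4-dichlorophenyl in place of 3-(trifluoromethyl)phenyl on an amide-type nitrogen likewise leaves the two compounds unseparated (a 1.3-fold lower number from compound 1 to compound 3 (0.12 log units; within the scatter)). Nothing available explains why either change leaves the number inside the scatter.

The compounds shown leave open whether an ethyl or benzyl group on this oxygen, or an amine in place of the hydroxy, would give a step beyond the scatter in this assay. They also leave open whether the methoxy to hydroxy step would read the same with 3-(trifluoromethyl)phenyl on the amide-type nitrogen, since this change has so far been read only with 3,4-dichlorophenyl there.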